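Swapping Chloro for Bromo on the Aryl Substituent

This account rests on a few compounds, and the source may have more. Where it says the series, first, only, none or still open, it means among the compounds named here.

For the measured compounds named here, compound 3 `Cc1cc2occ(-c3nc(-c4ccccc4)c(-c4ccccc4)n3-c3ccc(Cl)cc3)c(=O)c2cc1Cl` gives 12500 nM in a functional assay on MCF7 cells (Homo sapiens) for inhibition, read by MTT assay, with a stated time of 72 h (a higher number here means a weaker inhibitor, a lower number a stronger inhibitor), the highest of the three numbers measured so far. Compound 1 `Cc1cc2occ(-c3nc(-c4ccccc4)c(-c4ccccc4)n3-c3ccc(Cl)c(Cl)c3)c(=O)c2cc1Cl` gives 1560 nM, and compound 2 `Cc1ccc(-n2c(-c3coc4cc(C)c(Cl)cc4c3=O)nc(-c3ccccc3)c2-c2ccccc2)c(C)c1` gives 6250 nM. The step of an 8.0-fold higher number from compound 1 to compound 3 (0.90 log units; beyond the scatter) lies beyond the scatter, whereas a 2.0-fold higher number from compound 2 to compound 3 (0.30 log units; within the scatter) does not. Compound 4 `Cc1cc2occ(-c3nc(-c4ccccc4)c(-c4ccccc4)n3-c3ccc(Br)cc3)c(=O)c2cc1Cl` differs from compound 3 by bromo in place of chloro on an aromatic carbon. Going by the values given here, no measured step exchanges one halogen for another on that ring; the nearest comparison, an 8.0-fold higher number from compound 1 to compound 3 (0.90 log units; beyond the scatter), removes a chloro rather than replacing it, so it bears only loosely on this change. For compound 4 the expected step is therefore small, a 1.4-fold lower number from compound 3 to compound 4 (0.14 log units; within the scatter), with no clear direction beyond the scatter. Compound 4 is estimated at 9000 nM, within a range from 3000 nM to 27000 nM.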

Compound 4, half-maximal inhibitory concentration: 1560 nM
Beside the measured number, compound 4's estimate is 5.8-fold (0.76 log units) above it; measured number below the stated range.
By their numbers in this assay, from the lowest: compounds 1 and 4 (each within the scatter of the next); then compounds 2 and 3 (each within the scatter of the next).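

In this assay, this position proves sensitive to which halogen it carries: the change from 4-chlorophenyl to 4-bromophenyl alone gives a clear gain (an 8.0-fold lower number from compound 3 to compound 4 (0.90 log units; beyond the scatter)). The bromo compound also beats the 2,4-dimethylphenyl analogue (a 4.0-fold lower number from compound 2 to compound 4 (0.60 log units; beyond the scatter)) and sits level with the 3,4-dichlorophenyl analogue (no change at the digits printed from compound 1 to compound 4 (within the scatter)), so a single bromo reaches what two chloro groups reach here. Nothing available here explains the gain. From the compounds shown here alone, whether iodo or methoxy at this position would hold or extend it remains open.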